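A few compounds are considered here, and "the series" means these few. Any claim that something is new, unique, unknown or untested is made for them only; others in the source may bear on it.

Measured compounds:
compound 1, `CC(=O)Oc1ccc(C(=O)Nc2cc3ccc(OCC4CCN(C)C4)c(C)c3oc2=O)cc1CC=C(C)C`, 1880 nM
compound 2, `CC(C)=CCc1cc(C(=O)Nc2cc3ccc(OCC4CCN(C)C4)c(C)c3oc2=O)ccc1O`, 1550 nM

Both compounds were tested in a functional assay on MCF7 cells (Homo sapiens) for antiproliferative activity; a higher number here means a weaker inhibitor, a lower number a stronger inhibitor. On the two numbers available, compound 2 stands at 1550 nM, and it sits level with compound 1, since a 1.2-fold lower number from compound 1 to compound 2 (0.08 log units; within the scatter) lies within the scatter; the two compounds are not separated by this assay.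

Compound 3, `CCN(C)CCCOc1ccc2cc(NC(=O)c3ccc(O)c(CC=C(C)C)c3)c(=O)oc2c1C`, keeps everything in compound 2 except for one change: 2-(ethyl(methyl)amino)ethyl in place of 1-methylpyrrolidin-3-yl on a saturated chain carbon bound to an oxygen on an aromatic ring. Going by the values given here, the only measured step concerns a hydrogen in place of acetyl on an oxygen on an aromatic ring, which is a different part of the molecule, so no measured step bears on the present change. With nothing to point either way, compound 3 is expected to stay within the scatter of compound 2, which is what a 1.0-fold lower number from compound 2 to compound 3 (0.01 log units; within the scatter) means. The estimate for compound 3 in this assay is 1500 nM, with a range from 600 nM to 4000 nM.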

Compound 3, half-maximal inhibitory concentration: 2190 nM
Compound 3: the middle estimate sits 1.5-fold (0.16 log units) below what was measured; low and high end bracket the measured number.
By their numbers in this assay, from the lowest: compounds 2, 1 and 3 (each within the scatter of the next).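

In this assay, putting the open-chain 2-(ethyl(methyl)amino)ethyl in place of 1-methylpyrrolidin-3-yl on a saturated chain carbon bound to an oxygen on an aromatic ring gives a 1.4-fold higher number from compound 2 to compound 3 (0.15 log units; within the scatter), so this assay does not separate the two groups. The earlier pair spoke only to hydrogen against acetyl on an oxygen on an aromatic ring, whereas this pair bears on the amine-carrying group itself: a group with no ring and the same count of heavy atoms stands level with the five-membered ring. No measurement is at hand that would explain this result.

The compounds shown leave open whether a morpholine or a carboxylic acid in this place would stay level with compound 2. They also leave open whether the open chain would read the same with acetyl on the oxygen, as in compound 1.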